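Replacing a small ring with a short alkenyl chain

This account rests on a few compounds, and the source may have more. Where it says the series, first, only, none or still open, it means among the compounds named here.

Three compounds have been measured in a functional assay on MCF7 cells (Homo sapiens) for antiproliferative activity; a lower number here means a stronger inhibitor, a higher number a weaker inhibitor:
Compound 1 `COc1cc(Cc2nc3c(N)ncnc3n2CC2CCCCC2)cc(OC)c1OC` gives 39800 nM.
Compound 2 `CC/C=C/Cn1c(Cc2cc(OC)c(OC)c(OC)c2)nc2c(N)ncnc21` gives 46800 nM.
Compound 3 `COc1cc(Cc2nc3c(N)ncnc3n2CC2(C)CC2)cc(OC)c1OC` gives 112000 nM.

Compound 3 has the highest number of the three, beyond the scatter in both steps: a 2.8-fold higher number from compound 1 to compound 3 (0.45 log units; beyond the scatter) and a 2.4-fold higher number from compound 2 to compound 3 (0.38 log units; beyond the scatter). The step now followed leads to compound 4 `C/C=C/Cn1c(Cc2cc(OC)c(OC)c(OC)c2)nc2c(N)ncnc21`. The change is prop-1-en-1-yl in place of 1-methylcyclopropyl on a saturated chain carbon bound to an aromatic nitrogen. Within the data shown here, the most relevant measured step is the one from compound 2 to compound 3, a modest rise when the but-1-en-1-yl gave way to the 1-methylcyclopropyl; the step from compound 1 to compound 2 between an open chain and a ring stayed within the scatter. A modest fall in this assay is therefore expected, roughly undoing that rise, so a 2.0-fold lower number from compound 3 to compound 4 (0.31 log units; beyond the scatter) is the estimated step. Compound 4 is estimated at 55000 nM, with a range from 25000 nM to 120000 nM.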

Compound 4, half-maximal inhibitory concentration: 51300 nM
Estimate against measurement, compound 4: 1.1-fold (0.03 log units) above, within the range that was stated.
By their numbers in this assay, from the lowest: compounds 1, 2 and 4 (each within the scatter of the next); then compound 3.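

In this assay, prop-1-en-1-yl in place of 1-methylcyclopropyl on a saturated chain carbon bound to an aromatic nitrogen gives a 2.2-fold lower number from compound 3 to compound 4 (0.34 log units; beyond the scatter). Removing the terminal methyl of the alkenyl chain makes no readable difference, with a 1.1-fold higher number from compound 2 to compound 4 (0.04 log units; within the scatter), and prop-1-en-1-yl in place of cyclohexyl also stays within the scatter, with a 1.3-fold higher number from compound 1 to compound 4 (0.11 log units; within the scatter). Among these compounds, only the 1-methylcyclopropyl group stands apart, and nothing available explains why. Still open, from the compounds shown here alone, is whether a longer chain, or an amine or carboxylic acid on the chain, would move the number beyond the scatter of compound 1, compound 2 and compound 4.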